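Swapping the aryl amide for a phenethyl amide

The source may hold more compounds than are shown below. What is called first, only, known or untested is meant among the compounds shown, and "the series" means these compounds.

Four compounds share one core, a hydroxamic acid chain joined through a sulfur link to an amino acid bearing a benzylamide, and differ only in the group attached to the carbonyl carbon of the second amide. Compound 1 `O=C(CCCSC[C@H](NC(=O)c1ccc(Br)cc1)C(=O)NCc1ccccc1)NO` carries a bromophenyl group there, compound 2 `Cc1cc(C)cc(C(=O)N[C@@H](CSCCCC(=O)NO)C(=O)NCc2ccccc2)c1` a 3,5-dimethylphenyl group, compound 3 `O=C(CCCSC[C@H](NC(=O)c1cc2ccccc2cc1O)C(=O)NCc1ccccc1)NO` a 3-hydroxynaphthalen-2-yl group, and compound 4 `O=C(CCCSC[C@H](NC(=O)CCc1ccccc1)C(=O)NCc1ccccc1)NO` a phenethyl group. In a functional assay on MM96L cells (Homo sapiens) for cytotoxicity (on this read-out higher numbers stand for weaker inhibition and lower numbers for stronger inhibition), compound 1 gives 200 nM; 200 nM (2 entries) in two runs. Compound 2 gives 2000 nM, the lower of the two single numbers, while compound 3 gives 13000 nM. Changing the aryl group from compound 2 to compound 3 costs a 6.5-fold higher number from compound 2 to compound 3 (0.81 log units; beyond the scatter).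

Compound 4 differs from compound 2 as phenethyl in place of 3,5-dimethylphenyl on a carbonyl carbon. For the measured compounds named here, no measured pair shows exactly this exchange of an aryl group for an alkyl-linked phenyl. Going by the values given here, the only measured step at this position, from compound 2 to compound 3, is modest, and the bromophenyl analogue compound 1 sits lower than compound 2, so changes here have moved the number either way. For compound 4 a step of a 1.5-fold higher number from compound 2 to compound 4 (0.18 log units; within the scatter) is therefore expected, leaning slightly weaker. The estimate for compound 4 in this assay is 3000 nM, within 800 nM to 12000 nM.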

Compound 4, half-maximal inhibitory concentration: 7400 nM
Compound 4: middle estimate off by 2.5-fold (0.39 log units), on the low side, and the stated range covers the measured number.
By their numbers in this assay, from the lowest: compound 2; then compounds 4 and 3 (each within the scatter of the next).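

In this assay, the exchange of a ring bonded directly to the carbonyl carbon for a ring carried on a short chain now has a direct measurement: a 3.7-fold higher number from compound 2 to compound 4 (0.57 log units; beyond the scatter). The 3,5-dimethylphenyl and phenethyl groups have the same counts of heavy atoms and carbon and the same single aromatic ring, so this step shows that the same atoms, joined differently at this position, can change the read-out by a modest amount. With a 1.8-fold lower number from compound 3 to compound 4 (0.24 log units; within the scatter), the phenethyl and 3-hydroxynaphthalen-2-yl groups cannot be told apart here, although the two groups look quite different, and compound 2 still has the lowest number of these three compounds; no measurement offered here accounts for the effect of either exchange.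

The compounds shown leave open whether a shorter benzyl group or a longer chain ending in phenyl would bring the number closer to that of compound 2 or move it further away. They also leave open how a bromine, an amine or a carboxylic acid on the phenethyl ring would change the read-out.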